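Swapping the hydroxy of compound 3 for a 3-chlorophenoxy group

The source may report more compounds than this note shows. Statements on the series, on what has been measured and on what is new or still open speak of the compounds shown alone.

Among the compounds with values here, compound 3 `Cc1cc(O)c(S(C)(=O)=O)cc1C(=O)N=C(N)N` gives 220 nM in a functional assay for inhibition of sodium/hydrogen exchanger (Oryctolagus cuniculus) (on this read-out higher numbers stand for weaker inhibition and lower numbers for stronger inhibition), the highest number among the three compounds measured so far. Its nearest neighbour is compound 1 `Cc1cc(-c2ccc(Cl)cc2)c(S(C)(=O)=O)cc1C(=O)N=C(N)N`, which gives 45 nM, and the furthest is compound 2 `Cc1cc(-c2ccccc2)c(S(C)(=O)=O)cc1C(=O)N=C(N)N`, which gives 19 nM. The gaps are a 4.9-fold higher number from compound 1 to compound 3 (0.69 log units; beyond the scatter) and a 12-fold higher number from compound 2 to compound 3 (1.06 log units; beyond the scatter), while between the two aryl compounds there is a 2.4-fold lower number from compound 1 to compound 2 (0.37 log units; beyond the scatter).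

Compound 4 `Cc1cc(Oc2cccc(Cl)c2)c(S(C)(=O)=O)cc1C(=O)N=C(N)N` arises from compound 3 by a single change: 3-chlorophenyl in place of hydrogen on an oxygen on an aromatic ring. Within the data shown here, the steps that bear on this are the two that exchange an aryl group for hydroxy, both of which moved the number up sharply, and the one that added a chloro to the ring, which moved it up modestly. Among the measured compounds shown here, compound 4 keeps an aromatic ring in that region but attaches it through the oxygen that compound 3 carries, a connection none of the measured compounds share, so the exact size of the effect is uncertain. For compound 4 the number in this assay is therefore expected to fall well below that of compound 3, a step of a 3.7-fold lower number from compound 3 to compound 4 (0.56 log units; beyond the scatter). The estimate for compound 4 is 60 nM, with a range from 20 nM to 200 nM.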

Compound 4, half-maximal inhibitory concentration: 21 nM
The estimate for compound 4 lay 2.9-fold (0.46 log units) above the measured number; measured number inside the range.
By their numbers in this assay, from the lowest: compounds 2 and 4 (each within the scatter of the next); then compound 1; then compound 3.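

In this assay, putting 3-chlorophenyl on the oxygen of compound 3 gives a 10-fold lower number from compound 3 to compound 4 (1.02 log units; beyond the scatter), which shows that this position accepts an aryl group reached through an oxygen and not only one bonded directly to the aromatic carbon, as in compounds 1 and 2. Against the directly attached phenyl, the change to 3-chlorophenoxy gives a 1.1-fold higher number from compound 2 to compound 4 (0.04 log units; within the scatter), so the two groups cannot be told apart on this read-out, while against the directly attached 4-chlorophenyl it gives a 2.1-fold lower number from compound 1 to compound 4 (0.33 log units; beyond the scatter). A chloro-bearing aryl group at this position is therefore not tied to the number of compound 1, although this last swap alters the link and the place of the chloro together, so it cannot show which of the two matters.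

No measurement at hand gives a reason for any of these steps. The compounds shown leave open whether plain phenoxy or 4-chlorophenoxy would match compound 4, and whether an amine link or a methylene link in place of the oxygen would serve as well.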